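The source may hold more compounds than are shown below. What is called first, only, known or untested is meant among the compounds shown, and "the series" means these compounds.

Compound 1 `CNC(=O)c1ccc(-c2cnc(NCc3c(F)ccc4c3CCO4)c3cn[nH]c(=O)c23)c(C)n1`: 19000 nM
Compound 2 `Cc1ncccc1-c1cnc(NCc2c(F)ccc3c2CCO3)c2n[nH]c(=O)n12`: < 2000 nM

Going by the values given here, in a physicochemical assay for solubility, read by LC-MS, in phosphate buffer, with a stated time of 24 h, at pH 7.4 (a lower number here means a less soluble compound, a higher number a more soluble compound), compound 1 gives 19000 nM, the only number among the values shown. For compound 2 this assay reports only a limit, < 2000 nM (the limit of < 2000 nM in this assay, at which 1 of the 2 values shown sits). Compound 3 `Cc1ncccc1-c1cnc(NCc2c(F)ccc3c2CCO3)c2cn[nH]c(=O)c12` differs from compound 1 by hydrogen in place of methylcarbamoyl on an aromatic carbon. Among the compounds with values here, no pair of measured compounds differs in one place, so the size of such a step cannot be read from the data. Compound 3 is nonetheless expected to sit lower than compound 1, with a step of a 3.2-fold lower number from compound 1 to compound 3 (0.50 log units; beyond the scatter) beyond the usual scatter. The solubility of compound 3 is estimated at 6000 nM, between 2000 nM and 19000 nM.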

Compound 3, solubility: < 2000 nM
Compound 3 gave a limit, no number (the forecaster's own chance of this, stated with the estimate: 25%); middle value at least 3.0-fold (0.47 log units) away from the limit.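

In this assay, the position next to the ring nitrogen now has a measured step: hydrogen in place of methylcarbamoyl gives an at least 9.5-fold lower number from compound 1 to compound 3 (0.97 log units; beyond the scatter). Going by these compounds alone, this is the first comparison of compounds that differ in one place, and it shows that the change at this position exceeds the scatter. Compound 3 gives only a limit, so the step sets a bound and not a size: the limit of < 2000 nM in this assay, at which 2 of the 3 values shown sit.

Going by these compounds, how an amine, a carboxylic acid or a longer chain on the amide would read at this position stays open. So does whether the methylcarbamoyl group behaves the same way on another core.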